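The compounds below may be only part of what the source reports. "The series", "measured", "known", "first", "only" and "open" are said of these compounds alone.

In an ADME assay on microsomes from liver (Homo sapiens) for pharmacokinetics, read by LC-MS, with a stated time of 60 min, tested at 1 uM (a higher number here means faster removal of the compound, a lower number slower removal), compound 1 `C[C@@H]1CN(S(=O)(=O)c2ccc(NC(=O)NCc3cccnc3)cc2)C[C@H](C)O1` gives 17 mL/min/kg and compound 2 `N[C@H]1CC[C@H](NS(=O)(=O)c2ccc(NC(=O)NCc3cccnc3)cc2)CC1` gives 5 mL/min/kg, the lower of the two numbers. Within the data shown here, the only measured step, a 3.4-fold lower number from compound 1 to compound 2 (0.53 log units; beyond the scatter), placed (4-aminocyclohexyl)amino on a sulfonyl sulfur in place of 2,6-dimethylmorpholin-4-yl. Compound 3 `O=C(NCc1cccnc1)Nc1ccc(S(=O)(=O)N[C@H]2CC[C@H](O)CC2)cc1` changes that group further: hydroxy in place of amino on a saturated ring carbon. Among the measured compounds shown here, no measured step covers this swap, so it offers only weak guidance. A small rise is expected, a 1.4-fold higher number from compound 2 to compound 3 (0.15 log units; within the scatter). The estimated value for compound 3 is 7 mL/min/kg, with a range from 3.5 mL/min/kg to 14 mL/min/kg.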

Compound 3, clearance: 2 mL/min/kg
Estimate against measurement, compound 3: 3.5-fold (0.54 log units) above, outside the stated range (below it).
By their numbers in this assay, from the lowest: compound 3; then compound 2; then compound 1.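

In this assay, hydroxy in place of amino on the saturated ring carbon gives a 2.5-fold lower number from compound 2 to compound 3 (0.40 log units; beyond the scatter) and so shows that this one atom matters, even though both groups carry the same computed donor and acceptor counts. Measured against 2,6-dimethylmorpholin-4-yl, (4-hydroxycyclohexyl)amino gives an 8.5-fold lower number from compound 1 to compound 3 (0.93 log units; beyond the scatter), the largest step among these compounds. Nothing available here explains why the number falls. On these data alone, whether a methoxy group or a carboxylic acid at this ring carbon would give a similar number remains open. So does whether the pattern would hold on a different core.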